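The source may hold more compounds than are shown below. What is called first, only, known or untested is meant among the compounds shown, and "the series" means these compounds.

Measured compounds:
- compound 1, `CC1(C)[C@@H]2CC3=N[C@@H](CCC(=O)O)C(=O)O[C@@]3(C)[C@H]1C2`, in an ADME assay on NIH3T3 cells (Mus musculus) for antiproliferative activity, read by sulforhodamine B assay, with a stated time of 48 h (a higher number here means a weaker inhibitor, a lower number a stronger inhibitor), compound 1 gives > 1200000 nM, which is a limit of the assay and not a number.
- compound 2, `C[C@@H]1N=C2C[C@@H]3C[C@@H](C3(C)C)[C@]2(C)OC1=O`, in this assay compound 2 gives > 2000000 nM, again a limit of the assay.
- compound 3, `CC(C)(C)OC(=O)CC[C@H]1N=C2C[C@H]3C[C@H](C3(C)C)[C@@]2(C)OC1=O`, in this assay compound 3 gives > 1200000 nM, once more a limit of the assay.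

For the measured compounds named here, compound 3 therefore stands where every value so far stands: at a limit. Going by the values given here, two of the three values sit at the limit of > 1200000 nM in this assay, at which 2 of the 3 values shown sit, one at the limit of > 2000000 nM in this assay, at which 1 of the 3 values shown sits, and no compound has a readable number. Among the compounds with values here, the only step between measured compounds, a step that the two limits leave unreadable from compound 1 to compound 2, is hydrogen in place of carboxymethyl on a saturated chain carbon bound to a saturated ring carbon, and its two limits leave its size unreadable.

Compound 4, `CC(C)(C)OC(=O)CC[C@@H]1N=C2C[C@@H]3C[C@@H](C3(C)C)[C@]2(C)OC1=O`, is the mirror image of compound 3: the two compounds have the same atoms and bonds and differ only in configuration as drawn: 4 of 4 stereo elements differ (all stereocentres are inverted: mirror images); a stereocentre at a saturated ring carbon is drawn R in compound 3 and S in compound 4; a stereocentre at a saturated ring carbon is drawn R in compound 3 and S in compound 4; a stereocentre at a saturated ring carbon is drawn R in compound 3 and S in compound 4; a stereocentre at a saturated ring carbon is drawn R in compound 3 and S in compound 4. Within the data shown here, no measured step bears on an inversion of all stereocentres, and the step from compound 1 to compound 2 gives no size to lean on. With nothing beyond limits for compound 3, compound 1 and compound 2, compound 4 is expected to stay at the same limit, so that a number no higher from compound 3 to compound 4 (the limit leaves the size open) is expected to be no readable step at all. Compound 4 is estimated at 1200000 nM, in the range 500000 nM to 3000000 nM.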

Compound 4, half-maximal inhibitory concentration: > 1000000 nM
Compound 4: only a limit was reported; the forecaster's own chance of this, stated with the estimate: 85%; the middle value is on the limit's open side.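

In this assay compound 4 gives > 1000000 nM, a limit of the assay and not a number. None of the steps linking compound 4 with compound 1, compound 2 and compound 3 can be read. The compounds shown leave open whether the mirror images compound 3 and compound 4 differ at all in this assay.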